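Extending the Amine Linker by One Carbon

This account rests on a few compounds, and the source may have more. Where it says the series, first, only, none or still open, it means among the compounds named here.

Of the compounds shown here, two have so far been measured in a functional assay on HepG2 cells (Homo sapiens) for cytotoxicity, read by MTT assay, with a stated time of 72 h; on this read-out lower numbers stand for stronger inhibition and higher numbers for weaker inhibition. Compound 1 `COc1ccc(-c2cc(=O)c3c(O)cc(OCCCCN4CCN(C)CC4)c(OC)c3o2)cc1` gives 4200 nM. Compound 2 `CCN(CC)CCCOc1c(OCc2ccccc2)cc(O)c2c(=O)cc(-c3ccccc3)oc12` gives 3010 nM, the lowest of the two numbers, with compound 1 standing within the scatter of it. Compound 3 `CCN(CC)CCCCOc1c(OCc2ccccc2)cc(O)c2c(=O)cc(-c3ccccc3)oc12` is compound 2 with (diethylamino)methyl in place of diethylamino on a saturated chain carbon, three bonds along the chain from an oxygen on an aromatic ring. For the measured compounds named here, no step between measured compounds shows what such a change does here, so no shift beyond the scatter is expected in this assay in either direction. Compound 3 is accordingly estimated at 2800 nM, with a range from 1200 nM to 7000 nM. The step this estimate means, a 1.1-fold lower number from compound 2 to compound 3 (0.03 log units; within the scatter), is expected to stay within the scatter.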

Compound 3, half-maximal inhibitory concentration: 1650 nM
Beside the measured number, compound 3's estimate is 1.7-fold (0.23 log units) above it; low and high end bracket the measured number.
By their numbers in this assay, from the lowest: compounds 3, 2 and 1 (each within the scatter of the next, the first and the last beyond it).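

In this assay, for the compounds shown here, the change from 3-(diethylamino)propyl to 4-(diethylamino)butyl gives a 1.8-fold lower number from compound 2 to compound 3 (0.26 log units; within the scatter) and so offers the first reading of chain length at this position: on this core, the longer chain leaves the number within the scatter. No evidence on the cause of this step is at hand. As far as these compounds go, whether a still longer chain, 5-(diethylamino)pentyl, would move the number beyond the scatter remains open. So does the effect of a morpholine or pyrrolidine in place of diethylamino on either chain.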